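The source may hold more compounds than are shown below. What is called first, only, known or untested is meant among the compounds shown, and "the series" means these compounds.

Measured compounds:
compound 1 `COc1ccc(CN(C(C)=O)c2cc(OC)c(OC)c(OC)c2)cc1O` gives 79 nM in a functional assay on MGC-803 cells (Homo sapiens) for inhibition, read by MTT assay, with a stated time of 48 h; a lower number here means a stronger inhibitor, a higher number a weaker inhibitor;
compound 2 `C/C=C/C(=O)N(Cc1ccc(OC)c(C)c1)c1cc(OC)c(OC)c(OC)c1` gives 14500 nM;
compound 3 `C/C=C/C(=O)N(Cc1cccc(O)c1)c1cc(OC)c(OC)c(OC)c1` gives 14100 nM.

Compound 1 has the lowest number of the three, far from compound 2 and compound 3, which lie close to each other. Within the data shown here, the one measured step, a 1.0-fold lower number from compound 2 to compound 3 (0.01 log units; within the scatter), shows that exchanging the group on the saturated chain carbon bound to the amide-type nitrogen changes little between those two. Among the measured compounds shown here, no measured step touches the acyl side, which is where compound 4 `COc1ccc(CN(C(=O)/C=C/CBr)c2cc(OC)c(OC)c(OC)c2)cc1O` differs from compound 1: 3-bromoprop-1-en-1-yl in place of methyl on a carbonyl carbon. Compound 2 and compound 3, which both carry an unsaturated acyl group rather than acetyl, sit at much higher numbers than compound 1, but they also differ from compound 1 on the other side of the nitrogen, so their values bear only loosely on the present step. On that weak basis, compound 4 is expected to give a higher number, a 13-fold higher number from compound 1 to compound 4 (1.10 log units; beyond the scatter), with wide uncertainty; its estimated value is 1000 nM, likely between 100 nM and 10000 nM.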

Compound 4, half-maximal inhibitory concentration: 71 nM
Compound 4: the middle estimate sits 14-fold (1.15 log units) above what was measured; the measured number lies below the stated range.
By their numbers in this assay, from the lowest: compounds 4 and 1 (each within the scatter of the next); then compounds 3 and 2 (each within the scatter of the next).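

In this assay, among these compounds, the first measured step on the acyl side, a 1.1-fold lower number from compound 1 to compound 4 (0.05 log units; within the scatter), puts the two compounds level within the scatter. It shows that, on a carbonyl carbon whose other neighbour is the amide-type nitrogen, the larger 3-bromoprop-1-en-1-yl with its bromine and double bond is tolerated as well as methyl, at least on the core of compound 1. No measurement available here accounts for this result.

The compounds shown leave open whether the bromine or the double bond matters on its own, since a plain prop-1-en-1-yl group, without bromine, does not appear among them. They also leave open how this carbonyl position would respond to a longer saturated chain or an amine.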